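Tolerance of the shared core across three amide side chains

The source may report more compounds than this note shows. Statements on the series, on what has been measured and on what is new or still open speak of the compounds shown alone.

Three compounds share one core and differ only in the group on the amide nitrogen. In an ADME assay on CEM-SS cells (Homo sapiens) for cytotoxicity, read by XTT assay, with a stated time of 6 days (a lower number here means that less compound is tolerated, a higher number that more compound is tolerated), compound 1 `CCCC(=O)OCSc1ccccc1C(=O)NCCCCCNC(C)=O` gives 9.2 uM, the lowest of the three numbers. Compound 2 `CCCC(=O)OCSc1ccccc1C(=O)Nc1cccc(C(N)=O)c1` gives 17.5 uM in this assay, within the scatter of compound 1, so no order between them is claimed. Among the compounds with values here, compound 3 `CCCC(=O)OCSc1ccccc1C(=O)N(C)CC(=O)N(C)C` gives 57.3 uM in this assay, beyond the scatter from compound 1 and the only value here that is clearly set apart.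

Compound 4 `CCCC(=O)OCSc1ccccc1C(=O)NCC(=O)NC(C)(C)C` has not yet been measured. It differs from compound 1 in one place: (tert-butyl)carbamoyl in place of 4-acetamidobutyl on a saturated chain carbon bound to an amide-type nitrogen. Within the data shown here, no measured pair in the set shows this exact change, so the expected size of the step rests on the spread of the three values alone. A step from compound 1 toward a higher number is expected because compound 3 gives 57.3 uM with a side chain that, like the (tert-butyl)carbamoyl of compound 4, carries a second amide; the step is estimated as a 2.2-fold higher number from compound 1 to compound 4 (0.34 log units; beyond the scatter), which is expected to sit at the edge of the scatter. Compound 4 is therefore estimated at 20 uM in this assay, with a range from 8 uM to 50 uM.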

Compound 4, half-maximal toxic concentration: 46.8 uM
Compound 4: middle estimate off by 2.3-fold (0.37 log units), on the low side; low and high end bracket the measured number.
By their numbers in this assay, from the lowest: compounds 1 and 2 (each within the scatter of the next); then compounds 4 and 3 (each within the scatter of the next).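

Placing (tert-butyl)carbamoyl in place of 4-acetamidobutyl on a saturated chain carbon bound to an amide-type nitrogen gives, in this assay, a 5.1-fold higher number from compound 1 to compound 4 (0.71 log units; beyond the scatter), the first step in the series that can be read at a single place. Both groups have no ring and no net charge and match in hydrogen-bond donors and acceptors, so these counts do not separate them, yet the step lies beyond the scatter. No measurement available on the series accounts for the step.

As far as these compounds go, with one step, it remains open whether the higher number belongs to the tert-butyl end, the carbamoyl group or the shorter chain. A carboxylic acid or a primary amine at this place would test how far the higher number extends beyond these neutral amide side chains.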